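Sulfur side chains in an antiproliferative series

This account rests on a few compounds, and the source may have more. Where it says the series, first, only, none or still open, it means among the compounds named here.

Measured so far in a functional assay on HT cells (Homo sapiens) for antiproliferative activity, read by fluorescence, with a stated time of 72 h; a higher number here means a weaker inhibitor of growth, a lower number a stronger inhibitor of growth:
- compound 1 `CSc1nc(NCc2ccc(-c3ccccn3)cc2)c2[nH]nc(C(C)C)c2n1` gives 783 nM
- compound 2 `CC(C)c1n[nH]c2c(NCc3ccc(-c4ccccn4)cc3)nc(SC(C)C(C)O)nc12` gives 190 nM
- compound 3 `CC(C)c1n[nH]c2c(NCc3ccc(-c4ccccn4)cc3)nc(SCCCN(C)C)nc12` gives 105 nM

Compound 3 sits at the low end of these three numbers, but it shares that end with one neighbour, and the gap between them is within the scatter (a 1.8-fold lower number from compound 2 to compound 3 (0.26 log units; within the scatter)). The remaining compound lies further off (a 7.5-fold lower number from compound 1 to compound 3 (0.87 log units; beyond the scatter)).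

The next compound, compound 4 `CC(C)c1n[nH]c2c(NCc3ccc(-c4ccccn4)cc3)nc(SC3CCCCC3O)nc12`, carries 2-hydroxycyclohexyl in place of 3-(dimethylamino)propyl on a sulfur. The closest measured group is the 2-hydroxy-1-methylpropyl of compound 2, which gives 190 nM and also stands well clear of the methyl starting point (a 4.1-fold lower number from compound 1 to compound 2 (0.62 log units; beyond the scatter)). Among the compounds with values here, the two larger groups measured so far therefore do not separate in this assay, although only two such groups have been tested. Within the data shown here, no measured compound has a ring in this group, so the range has to stay wide.

Among the measured compounds shown here, a small rise is expected, with no step clearly beyond the scatter (a 1.7-fold higher number from compound 3 to compound 4 (0.23 log units; within the scatter)). The estimate for compound 4 is 180 nM with an expected range of (70 nM to 450 nM).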

Compound 4, concentration for 50% growth inhibition: 636 nM
The estimate for compound 4 lay 3.5-fold (0.55 log units) below the measured number; the whole stated range lies below it.
By their numbers in this assay, from the lowest: compounds 3 and 2 (each within the scatter of the next); then compounds 4 and 1 (each within the scatter of the next).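

At this sulfur, size alone does not carry the gain over methyl in this assay: the 2-hydroxycyclohexyl of compound 4 and the methyl of compound 1 are not separated (a 1.2-fold lower number from compound 1 to compound 4 (0.09 log units; within the scatter)). Nor does a hydroxy group on the side chain secure the gain, as the open-chain 2-hydroxy-1-methylpropyl and the ring-bearing 2-hydroxycyclohexyl are clearly apart (a 3.3-fold higher number from compound 2 to compound 4 (0.52 log units; beyond the scatter)), and the step away from 3-(dimethylamino)propyl is of similar size (a 6.1-fold higher number from compound 3 to compound 4 (0.78 log units; beyond the scatter)), so among the three larger groups shown, only the one with a six-membered ring fails to hold the gain. No measurement shown here accounts for the difference between the ring and the open chains.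

The compounds shown cannot tell whether the loss belongs to the ring itself or to the hydroxy group on it, a question that plain cyclohexyl, or a ring containing an amine such as piperidinyl, would bear on. Also open, on these data alone, is how the value responds to the length of the dimethylamino chain, and whether a carboxylic acid at the end of a propyl chain would fall with the open-chain groups.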